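This account rests on a few compounds, and the source may have more. Where it says the series, first, only, none or still open, it means among the compounds named here.

Compound 2 `O=C(Nc1ccc(Oc2ccnc3[nH]ccc23)c(F)c1)c1cn(-c2ccc(F)c(Cl)c2)c2ccccc2c1=O` is the weaker of the two compounds measured in a functional assay on A549 cells (Homo sapiens) for inhibition, read by MTT assay, with a stated time of 72 h; a lower number here means a stronger inhibitor, a higher number a weaker inhibitor: compound 2 gives 2150 nM, while compound 1 `O=C(Nc1ccc(Oc2ccnc3[nH]ccc23)c(F)c1)c1cn(-c2ccccc2)c2ccccc2c1=O` gives 420 nM. For the measured compounds named here, the one step measured so far, a 5.1-fold higher number from compound 1 to compound 2 (0.71 log units; beyond the scatter), came from exchanging the plain phenyl on the aromatic nitrogen for the halogenated ring. Compound 3 `COc1ccc(-n2cc(C(=O)Nc3ccc(Oc4ccnc5[nH]ccc45)c(F)c3)c(=O)c3ccccc32)cc1` differs from compound 2 at the same place: 4-methoxyphenyl in place of 3-chloro-4-fluorophenyl on an aromatic nitrogen. Going by the values given here, only the step from compound 1 to compound 2 bears on this change, and it shows that a substituent pattern on this ring can move this assay by a modest but real amount. Compound 3 is expected to give a number somewhat lower than compound 2, closer to compound 1, estimated as a 2.7-fold lower number from compound 2 to compound 3 (0.43 log units; beyond the scatter). The estimate for compound 3 in this assay is 800 nM, within a range from 250 nM to 2500 nM.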

Compound 3, half-maximal inhibitory concentration: 4150 nM
For compound 3 the middle estimate is 5.2-fold (0.71 log units) below the measured one; measured number above the stated range.
By their numbers in this assay, from the lowest: compound 1; then compounds 2 and 3 (each within the scatter of the next).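

In this assay, exchanging 3-chloro-4-fluorophenyl for 4-methoxyphenyl on the aromatic nitrogen gives a 1.9-fold higher number from compound 2 to compound 3 (0.29 log units; within the scatter), so these two quite different substituted rings cannot be told apart here. Adding the methoxy to the plain phenyl gives a 9.9-fold higher number from compound 1 to compound 3 (0.99 log units; beyond the scatter), which makes this the second substituted ring shown to be a weaker inhibitor than the unsubstituted phenyl, with no compound here going against that pattern. Nothing available explains this trend.

The compounds shown leave open whether any substituent on this ring gives the same result, or only these two; a ring carrying a single fluorine, a single chlorine or an amine would test that. Also open, on these data alone, is whether a ring is needed on this nitrogen at all, which a methyl group or a longer chain there could show.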